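A Pyrrolidinylcarbonyl Extension on the Ring Nitrogen Substituent

The compounds below may be only part of what the source reports. "The series", "measured", "known", "first", "only" and "open" are said of these compounds alone.

Of the compounds shown here, three built on a shared core have been measured in a functional assay on the whole organism with Rattus norvegicus as the target, read by paw edema, with a stated time of 3 h, at a dose of 100 mg/kg by the oral route; on this read-out lower numbers stand for less inhibition and higher numbers for more inhibition at the one dose given (going by the name of the read-out). Compound 1 `CCc1ccc(-c2nc3cc(O)ccc3[nH]2)nc1` gives 25% in this assay. Compound 2 `CCc1cccc(-c2nc3cc(C)ccc3[nH]2)n1` gives 10% in this assay. Compound 3 `CCc1ccc(-c2nc3ccccc3n2C)nc1` gives 5% in this assay, the lowest of the three numbers; its nearest neighbour is compound 2, whose number lies within the scatter of it, while compound 1 stands further off, beyond the scatter. No two of these compounds differ in a single place, so none of their gaps can be read as the effect of one change.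

Compound 4 `CCc1ccc(-c2nc3ccccc3n2CC(=O)N2CCCC2)nc1` has not yet been measured in this assay. It differs from compound 3 as follows: (pyrrolidin-1-yl)carbonyl in place of hydrogen on a saturated chain carbon bound to an aromatic nitrogen. Within the data shown here, nothing among the measured compounds shows what such a change does in this assay, so the expectation rests only on the low starting point of compound 3 at 5%. In this assay a step of no size beyond the scatter is expected from compound 3 to compound 4, a number 7 percentage points higher from compound 3 to compound 4 (within the scatter), with a modest upward drift the more likely direction if any. Compound 4 is therefore estimated at 12%, with a range from 0% to 30%.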

Compound 4, a percentage reported as inhibition, in the whole organism at one dose (the size of the read-out at that dose, not a potency): -5%
For compound 4 the middle estimate is 17 percentage points above the measured one; measured number outside the range, below it.
By their numbers in this assay, from the lowest: compounds 4, 3 and 2 (each within the scatter of the next, the first and the last beyond it); then compound 1.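

Among these compounds, on a saturated chain carbon bound to an aromatic nitrogen, placing (pyrrolidin-1-yl)carbonyl in place of hydrogen, which turns methyl into ((pyrrolidin-1-yl)carbonyl)methyl, gives in this assay a first step that can be read, a number 10 percentage points lower from compound 3 to compound 4 (within the scatter). The earlier compounds shown here could not show this, since no two of them differ in a single place; this pair shows that the position can carry the whole (pyrrolidin-1-yl)carbonyl group without a step that stands clear of the scatter, and the added group brings no gain here, with compound 4 at -5%. Nothing among the data given accounts for this result.

The compounds shown leave open whether a different group on the same chain carbon, such as a carboxylic acid, a primary amine or a longer chain ending in a morpholine ring, would give a step beyond the scatter. They also leave open how the same extension would read on a core carrying a hydroxy group, as in compound 1, which gives 25%.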